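Methylphenyl isomer step in mouse liver microsome clearance

The compounds below may be only part of what the source reports. "The series", "measured", "known", "first", "only" and "open" are said of these compounds alone.

Measured compounds:
- compound 1 `c1cc2c(s1)CCOC21CCN(Cc2ccc3c(c2)OCCO3)CC1`: > 30 mL/min/g
- compound 2 `c1cc2c(s1)CCOC21CCN(Cc2cnc3c(c2)OCCO3)CC1`: "not determined" (no result reported)
- compound 3 `Cc1ccc(CN2CCC3(CC2)OCCc2sccc23)cc1`: > 30 mL/min/g

In an ADME assay on microsomes from liver (Mus musculus) for metabolic stability, read by LC-MS, using NADPH, with a stated time of 30 min, tested at 0.5 uM (a lower number here means slower removal, a higher number faster removal of the compound), compound 1 gives > 30 mL/min/g, which is a limit of the assay rather than a number. For compound 2 the result in this assay is "not determined" (no result reported). Compound 3 gives > 30 mL/min/g in this assay, again only a limit. So compound 3 stands at the ceiling of the assay, together with compound 1, and no single number places it; this is the state described by the limit of > 30 mL/min/g in this assay, at which 2 of the 3 values shown sit.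

Compound 4 `Cc1cccc(CN2CCC3(CC2)OCCc2sccc23)c1` is the next compound, not yet measured. Its difference from compound 3: 3-methylphenyl in place of 4-methylphenyl on a saturated chain carbon bound to an amine nitrogen in a ring. The two have the same atoms, joined differently, and the change concerns only the position of the methyl on the phenyl ring.

With compound 3 already at the limit, no step beyond the scatter is expected in this assay; compound 4 is expected to stay at or near that limit, the step that the limit leaves unreadable from compound 3 to compound 4 being estimated as none beyond the scatter. The estimate for compound 4 is 35 mL/min/g, within 15 mL/min/g to 80 mL/min/g.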

Compound 4, intrinsic clearance in a liver preparation (reported as CLH), per the amount of preparation that the assay uses: > 30 mL/min/g
Compound 4 was reported as a limit; the forecaster's own chance of this, stated with the estimate: 70%; the middle value does not contradict the limit.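

In this assay no step can be read between compound 3 and compound 4, since both are reported only as limits: the limit of > 30 mL/min/g in this assay, at which 3 of the 4 values shown sit. The compounds shown leave open how fast compound 3 and compound 4 are actually removed, and whether the methyl position changes that removal at all.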